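The source may hold more compounds than are shown below. What is called first, only, known or untested is meant among the compounds shown, and "the series" means these compounds.

In a functional assay on MCF7 cells (Homo sapiens) for antiproliferative activity, tested at 1 uM (on this read-out lower numbers stand for less inhibition and higher numbers for more inhibition at the one concentration tested (going by the name of the read-out)), compound 1 `Cc1nn(C)c(Oc2ccc(Cl)cc2)c1/C=N/OCc1ccc([N+](=O)[O-])cc1` gives 27.1%, the highest of the three numbers recorded. Compound 2 `Cc1nn(C)c(Oc2ccccc2)c1/C=N/OCc1ccc([N+](=O)[O-])cc1` gives 24%, which lies within the scatter of compound 1, while compound 3 `CC(C)c1nn(-c2ccccc2)c(Oc2ccc(Cl)cc2)c1/C=N/OCc1ccc(C(=O)OC(C)(C)C)cc1` gives -4.9%, well below. For the measured compounds named here, the only single-place step known is a number 3.1 percentage points lower from compound 1 to compound 2 (within the scatter). Compound 4 `Cc1ccc(CO/N=C/c2c(C)nn(C)c2Oc2ccc(Cl)cc2)cc1` differs from compound 1 in one place: methyl in place of nitro on an aromatic carbon. Going by the values given here, no measured step touches this part of the molecule; the hydrogen-for-chloro step concerns a different ring, and compound 3 differs from compound 1 in several places at once, so its low number cannot be traced to any one of them. With compound 1 as the only anchor, the estimate for compound 4 is a modest downward lean, a number 7.1 percentage points lower from compound 1 to compound 4 (within the scatter). The estimated value for compound 4 is 20%, with a range from 5% to 35%.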

Compound 4, a percentage reported as inhibition, at one concentration (the size of the read-out at that concentration, not a potency): 30.7%
Compound 4: middle estimate off by 10.7 percentage points, on the low side; the range from low to high includes it.
By their numbers in this assay, from the lowest: compound 3; then compounds 2, 1 and 4 (each within the scatter of the next).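

For the compounds shown here, the change from 4-nitrophenyl to 4-methylphenyl gives a number 3.6 percentage points higher from compound 1 to compound 4 (within the scatter) in this assay and is the first step read at this position on the aromatic ring. In this pair, the number stays within the scatter with methyl in place of nitro, so the nitro group is not required to hold this level of inhibition. Nothing available explains this result. From the compounds shown here alone, what an amine, a carboxylic acid or a longer chain would give at this position remains open. Going by these compounds, whether the same exchange would hold without the chloro, as on compound 2, also remains open.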